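Phenyl to furan-2-yl on the amide carbonyl of compound 2

The compounds below may be only part of what the source reports. "The series", "measured", "known", "first", "only" and "open" are said of these compounds alone.

Going by the values given here, compound 1 `CCCCCCCCNC(=O)[C@@H](NC(=O)c1ccco1)[C@@H](C)O` and compound 2 `CCCCCCCCCCCCNC(=O)[C@@H](NC(=O)c1ccccc1)[C@@H](C)O` are the two measured members of this pair. In a functional assay on SiHa cells (Homo sapiens) for cytotoxicity, read by MTT assay, with a stated time of 48 h (a lower number here means a stronger inhibitor, a higher number a weaker inhibitor), compound 1 gives 124000 nM and compound 2 gives 63900 nM; the two numbers lie within the usual scatter of each other, so neither stands apart. Compound 3 `CCCCCCCCCCCCNC(=O)[C@@H](NC(=O)c1ccco1)[C@@H](C)O` is not yet measured. It differs from compound 2 by furan-2-yl in place of phenyl on a carbonyl carbon. Among the compounds with values here, no single step of this kind is known here, and the change is expected to be small: the step of a 1.3-fold higher number from compound 2 to compound 3 (0.12 log units; within the scatter) is estimated to stay within the scatter. Compound 3 is therefore expected at about 85000 nM, in a range from 40000 nM to 200000 nM.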

Compound 3, half-maximal inhibitory concentration: 64300 nM
For compound 3 the middle estimate is 1.3-fold (0.12 log units) above the measured one, within the range that was stated.
By their numbers in this assay, from the lowest: compounds 2, 3 and 1 (each within the scatter of the next).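

In this assay furan-2-yl in place of phenyl on the carbonyl carbon gives a 1.0-fold higher number from compound 2 to compound 3 (0.00 log units; within the scatter) and so gives no readable separation between these two rings, despite the hydrogen-bond acceptor counted for furan-2-yl. Butyl in place of hydrogen on the saturated chain carbon, eight bonds along the chain from the amide-type nitrogen, gives a 1.9-fold lower number from compound 1 to compound 3 (0.29 log units; within the scatter) and so also shows no step beyond the scatter. No measurement bears on the reason for either result.

Still open, on these data alone, is whether a carboxylic acid or an amine on the ring, or a longer chain, would separate from these compounds.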